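This account rests on a few compounds, and the source may have more. Where it says the series, first, only, none or still open, it means among the compounds named here.

Compound 1 `COc1cccc(OCC#Cc2ccc(C)cn2)c1`, compound 2 `COc1cccc(OCC#Cc2cc(C)ccn2)c1`, compound 3 `COc1cccc(OCC#Cc2nccs2)c1`; compound 4 `COc1cccc(OCC#Cc2cnccn2)c1` is not yet measured.

In a functional assay with metabotropic glutamate receptor 5 (Homo sapiens) as the target, read by FLIPR (a higher number here means a weaker inhibitor, a lower number a stronger inhibitor), compound 1 gives 7930 nM. For compound 2 this assay reports only a limit, > 10000 nM. For compound 3 the result is likewise a limit, > 10000 nM. For the measured compounds named here, compound 3 therefore stands at the limit of > 10000 nM in this assay, at which 2 of the 3 values shown sit, and the single numeric value in the set is not far from that limit either. The change to compound 4 is pyrazin-2-yl in place of 1,3-thiazol-2-yl on a triple-bonded carbon. Going by the values given here, no step between two measured compounds is known, so no direction can be drawn from the series itself; the expectation is a step no larger than the usual scatter, with compound 4 staying weak in this assay. Compound 4 is expected at 15000 nM, between 5000 nM and 50000 nM. The expected step is a step that the limit leaves unreadable from compound 3 to compound 4, most likely reported again only as a limit.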

Compound 4, half-maximal inhibitory concentration: > 10000 nM
Compound 4 was reported as a limit (the forecaster's own chance of this, stated with the estimate: 70%); the middle value lies beyond the limit too.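

In this assay compound 4 gives > 10000 nM, a limit. For the compounds shown here, compound 3 gives > 10000 nM, also a limit, so no step between compound 3 and compound 4 can be read. The compounds shown leave open whether pyrazin-2-yl and 1,3-thiazol-2-yl differ at all in this assay.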